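The source may hold more compounds than are shown below. What is called first, only, known or untested is meant among the compounds shown, and "the series" means these compounds.

Measured in a functional assay on HeLa cells (Homo sapiens) for cytotoxicity, read by MTT assay; a higher number here means a weaker inhibitor, a lower number a stronger inhibitor:
- compound 1 (`C=C[C@@](C)(/C=C/c1ccc(OC(C)(C)[C@@H](O)CC[C@@](C)(C=C)/C=C/c2ccc(O)cc2)cc1)CCC=C(C)C`) gives > 50000 nM
- compound 2 (`C=C[C@@](C)(/C=C/c1ccc(OC(C)=O)cc1)CCC=C(C)C`) gives 18100 nM

Compound 1 sits at > 50000 nM as a limit of the assay, not a number. For the measured compounds named here, compound 2 gives 18100 nM as the only true number so far.

Compound 3 (`C=C[C@@](C)(/C=C/c1ccc(OC)cc1)CCC=C(C)C`) has methyl in place of acetyl on an oxygen on an aromatic ring, the change methyl in place of acetyl on an oxygen on an aromatic ring that reads acetoxy to methoxy. Going by the values given here, no measured step shows what this change does, so from compound 2 at 18100 nM only a modest move toward weaker inhibition is expected, possibly none beyond the scatter. The estimated step of a 1.4-fold higher number from compound 2 to compound 3 (0.14 log units; within the scatter) is expected to stay small. Compound 3 is expected near 25000 nM (estimated range 10000 nM to 50000 nM).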

Compound 3, half-maximal inhibitory concentration: > 50000 nM
Compound 3 gave a limit, no number; the forecaster's own chance of this, stated with the estimate: 20%; middle value at least 2.0-fold (0.30 log units) away from the limit.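

For the compounds shown here, putting methyl in place of acetyl on an oxygen on an aromatic ring gives the first step that can be read in this assay: an at least 2.7-fold higher number from compound 2 to compound 3 (0.44 log units; beyond the scatter). The group on this oxygen therefore matters, and here acetoxy gives the stronger inhibitor of the two. Compound 3 stands at a limit, not a number, so the step has a minimum size but no known full size, because the assay reading stops there: the limit of > 50000 nM in this assay, at which 2 of the 3 values shown sit.

Still open, as far as these compounds go, is whether the carbonyl of the acetyl group matters, or simply the group's size. A longer acyl chain such as butyryl on this oxygen could help separate those two readings.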